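This account rests on a few compounds, and the source may have more. Where it says the series, first, only, none or still open, it means among the compounds named here.

Compound 2 `CC(=O)Nc1cc(NC(=O)Nc2ccc(C)c(C)c2)ccc1C` carries an acetamido group on the shared core. In a functional assay on A375P cells (Homo sapiens) for antiproliferative activity (a higher number here means a weaker inhibitor, a lower number a stronger inhibitor), compound 2 gives only a limit of the assay, > 30000 nM. Compound 1 `CC(=O)Nc1cc(NC(=O)Nc2cc(F)cc(C(F)(F)F)c2)ccc1C` likewise gives a limit, > 30000 nM. Compound 3 `Cc1ccc(NC(=O)Nc2cc(F)cc(C(F)(F)F)c2)cc1NC(=O)c1ccccc1` also gives a limit, > 30000 nM. Compound 4 `Cc1ccc(NC(=O)Nc2ccc(C)c(NC(=O)c3ccccc3)c2)cc1C` differs from compound 2 by phenyl in place of methyl on a carbonyl carbon. The same exchange has been made once before, from compound 1 to compound 3, as a step that the two limits leave unreadable from compound 1 to compound 3; that step cannot be read because of the limit of > 30000 nM in this assay, at which 3 of the 3 values shown sit. No readable step therefore bears on the change, and compound 4 is expected to remain at the limit, with a number no higher from compound 2 to compound 4 (the limit leaves the size open) expected to show nothing beyond the scatter. Compound 4 is accordingly estimated at 30000 nM, within a range from 10000 nM to 100000 nM.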

Compound 4, half-maximal inhibitory concentration: > 30000 nM
Compound 4 was reported as a limit; the forecaster's own chance of this, stated with the estimate: 85%; the middle value lies on the limit itself.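

No size can be read for the exchange of acetamido for benzamido from compound 2 to compound 4, because both values are limits: (the limit of > 30000 nM in this assay, at which 4 of the 4 values shown sit). The compounds shown leave open how strongly any of them acts and whether this exchange changes that at all.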